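Aryl in place of bromo on the shared core

A few compounds are considered here, and "the series" means these few. Any claim that something is new, unique, unknown or untested is made for them only; others in the source may bear on it.

Compound 1 `Brc1cn2ccnc2c(-c2ccc3ncn(C4CCCCC4)c3c2)n1` stands second highest of the three numbers in a functional assay on HCT-15 cells (Homo sapiens) for inhibition, read by sulforhodamine B assay, with a stated time of 48 h, tested at 10 uM (a lower number here means less inhibition, a higher number more inhibition at the concentration tested (going by the name of the read-out)), where compound 1 gives 13.1%. Compound 3 `Clc1ccc(-c2cn3ccnc3c(-c3ccc4ncn(C5CCCCC5)c4c3)n2)cc1` gives 15.5%, and compound 2 `c1cn2cc(-c3ccsc3)nc(-c3ccc4ncn(C5CCCCC5)c4c3)c2n1` gives 1.37%. The step of a number 2.4 percentage points higher from compound 1 to compound 3 (within the scatter) lies within the scatter, while a number 11.7 percentage points lower from compound 1 to compound 2 (beyond the scatter) and a number 14.1 percentage points higher from compound 2 to compound 3 (beyond the scatter) are modest. Compound 4 `FC(F)(F)c1cccc(-c2cn3ccnc3c(-c3ccc4ncn(C5CCCCC5)c4c3)n2)c1` differs from compound 1 by 3-(trifluoromethyl)phenyl in place of bromo on an aromatic carbon. The step from compound 1 to compound 3 bears most directly on compound 4, both changes bringing a six-membered aromatic ring of carbon only in place of bromo, and that step was within the scatter. The step to compound 2 is the only one beyond the scatter and runs downward. No step beyond the scatter is therefore expected in this assay, and the estimate for compound 4 is 15% (2% to 30%), meaning a number 1.9 percentage points higher from compound 1 to compound 4 (within the scatter).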

Compound 4, a percentage reported as inhibition, at one concentration (the size of the read-out at that concentration, not a potency): 0.36%
Estimate against measurement, compound 4: 14.6 percentage points above; measured number below the stated range.
By their numbers in this assay, from the lowest: compounds 4 and 2 (each within the scatter of the next); then compounds 1 and 3 (each within the scatter of the next).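

In this assay a six-membered aromatic ring of carbon only at this position does not settle the number: a number 15.1 percentage points lower from compound 3 to compound 4 (beyond the scatter), so the outcome depends on what that ring carries, and a number 12.7 percentage points lower from compound 1 to compound 4 (beyond the scatter), whereas compound 3 stays within the scatter of compound 1. The other step, a number 1 percentage points lower from compound 2 to compound 4 (within the scatter), places 3-(trifluoromethyl)phenyl level with thiophen-3-yl within the scatter. Nothing measured on these compounds accounts for the split. Open, from the compounds shown here alone, is whether the substituent itself or its place on the phenyl ring separates compound 3 from compound 4, and how an amine or a carboxylic acid on that ring would read.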